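The source may report more compounds than this note shows. Statements on the series, on what has been measured and on what is new or still open speak of the compounds shown alone.

Of the compounds shown here, two have numbers so far in a functional assay on PC-3 cells (Homo sapiens) for cytotoxicity, read by sulforhodamine B assay, with a stated time of 48 h; on this read-out lower numbers stand for stronger inhibition and higher numbers for weaker inhibition. Compound 1 `COc1cc(C2CC(c3ccco3)=NN2C(C)=O)cc(OC)c1OC` gives 9650 nM. Compound 2 `CC(=O)N1N=C(c2cccc3ccccc23)CC1c1ccccc1[N+](=O)[O-]` gives 3540 nM, the lower of the two numbers, and the gap between them lies beyond the usual scatter. Among the compounds with values here, these two differ in more than one place, so no single-change step is available as a guide to the next one.

Compound 3 `CC(=O)N1N=C(c2cccc3ccccc23)CC1c1ccco1` is still unmeasured. It has furan-2-yl in place of 2-nitrophenyl on a saturated ring carbon, and otherwise matches compound 2: furan-2-yl in place of 2-nitrophenyl on a saturated ring carbon. The size of this step in this assay remains uncertain. A small rise in the number is expected, of a size that may stay within the scatter. Within the data shown here, the only reference point is compound 1, which also carries a furan-2-yl group and stands at 9650 nM, although its other differences narrow what that value can show. The expected change is a 1.6-fold higher number from compound 2 to compound 3 (0.19 log units; within the scatter). For compound 3 the estimated value is 5500 nM, with an expected range of 1800 nM to 16000 nM.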

Compound 3, half-maximal inhibitory concentration: 18000 nM
Compound 3: middle estimate off by 3.3-fold (0.51 log units), on the low side, and the stated range ends below it.
By their numbers in this assay, from the lowest: compound 2; then compounds 1 and 3 (each within the scatter of the next).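

In this assay, within the data shown here, furan-2-yl in place of 2-nitrophenyl on the saturated ring carbon gives a 5.1-fold higher number from compound 2 to compound 3 (0.71 log units; beyond the scatter) as the first single-change step, so the group at this position moves the number by more than the scatter when the rest of compound 2 stays fixed. For this one pair, 2-nitrophenyl goes with the lower number, but the step swaps a six-membered aromatic ring of carbon only and its nitro substituent for a five-membered aromatic ring with a hetero atom, so it cannot show whether the ring or the substituent accounts for the difference. No measurement on hand bears on the reason for this step.

Still open, as far as these compounds go, is how an unsubstituted phenyl or thiophen-2-yl at this position would compare with 2-nitrophenyl and furan-2-yl, which would help separate the contribution of the ring from that of the substituent. Also open, from the compounds shown here alone, is whether an amine in place of the nitro group on the same phenyl ring would keep the lower number of compound 2, and whether the step has the same size with other groups elsewhere on the shared core.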